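Alkoxymethylamino analogues on the shared core: hexyl chain

The compounds below may be only part of what the source reports. "The series", "measured", "known", "first", "only" and "open" are said of these compounds alone.

Measured compounds in a functional assay on PC-3 cells (Homo sapiens) for cytotoxicity, read by MTT assay, with a stated time of 72 h; on this read-out lower numbers stand for stronger inhibition and higher numbers for weaker inhibition:
compound 1, `COCNc1n[n+]([O-])c2ccccc2[n+]1[O-]`, gives 7510 nM.
compound 2, `[O-][n+]1nc(NCOCc2ccc(C(F)(F)F)cc2)[n+]([O-])c2ccccc21`, gives 7650 nM.
compound 3, `COc1ccc(COCNc2n[n+]([O-])c3ccccc3[n+]2[O-])cc1`, gives 14500 nM.

Compound 3 carries the highest of the three numbers in this assay, but its gaps to compound 2 and to compound 1 both sit within the scatter, so no order among the three can be read from them.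

The next compound, compound 4, is `CCCCCCCOCNc1n[n+]([O-])c2ccccc2[n+]1[O-]`. Against compound 3 the change is hexyl in place of 4-methoxyphenyl on a saturated chain carbon bound to an oxygen on a saturated carbon.

Among the measured compounds shown here, the only step that touches this position is the one from compound 1 to compound 3, where a 4-methoxyphenyl enters on a saturated chain carbon bound to an oxygen on a saturated carbon: a 1.9-fold higher number from compound 1 to compound 3 (0.29 log units; within the scatter). The step from compound 2 to compound 3, a 1.9-fold higher number from compound 2 to compound 3 (0.28 log units; within the scatter), concerns a substituent on the aromatic ring that leaves in compound 4 and bears only indirectly. Neither step shows this position to move the number beyond the scatter. For compound 4 the expectation is therefore a step of about a 1.8-fold lower number from compound 3 to compound 4 (0.26 log units; within the scatter), not beyond the scatter, with the estimate for compound 4 put at 8000 nM in this assay, between 3000 nM and 25000 nM.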

Compound 4, half-maximal inhibitory concentration: 1210 nM
Compound 4: middle estimate off by 6.6-fold (0.82 log units), on the high side, outside the stated range (below it).
By their numbers in this assay, from the lowest: compound 4; then compounds 1, 2 and 3 (each within the scatter of the next).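

In this assay, the position on a saturated chain carbon bound to an oxygen on a saturated carbon now moves the number beyond the scatter, which neither earlier step showed. Hexyl in place of 4-methoxyphenyl gives a large step (a 12-fold lower number from compound 3 to compound 4 (1.08 log units; beyond the scatter)), and hexyl in place of hydrogen gives a modest one (a 6.2-fold lower number from compound 1 to compound 4 (0.79 log units; beyond the scatter)), so the lower number goes with the entry of hexyl against either partner, not only with the loss of 4-methoxyphenyl. No measurement at hand gives a reason for this shift.

Hexyl is the only saturated chain of this size shown, so the dependence on chain length remains open. An octyl chain, or a hexyl chain ending in an amine or a carboxylic acid, would test how far the lower number extends.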